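The compounds below may be only part of what the source reports. "The series", "measured", "known", "first", "only" and "open" are said of these compounds alone.

Compound 1 `O=C1Nc2c(O)cc(Cl)cc2[C@@](C#CC2CC2)(C(F)(F)F)O1` is measured in a functional assay for inhibition of Nucleic Acid (a lower number here means a stronger inhibitor, a higher number a weaker inhibitor), where compound 1 gives 63 nM. Among the two numbers known in this assay, that is the higher one. The nearest is compound 3 `O=C1Nc2ccc(Cl)cc2C(C#CC2(O)CC2)(C(F)(F)F)O1`, which gives 33 nM in this assay, a difference that sits within the usual scatter of repeated measurements, so the two cannot be ranked against each other. Compound 2 `O=C1Nc2c(O[C@@H]3O[C@H](C(=O)O)[C@@H](O)[C@H](O)[C@H]3O)cc(Cl)cc2[C@@](C#CC2CC2)(C(F)(F)F)O1` gives only a limit in this assay, > 985 nM, not a number; this is the limit of > 985 nM in this assay, at which 1 of the 3 values shown sits.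

The step under study leads from compound 1 to compound 4 `O=C1Nc2c(O)cc(Cl)cc2[C@](C#CC2CC2)(C(F)(F)F)O1`. The two compounds have the same atoms and bonds and differ only in configuration as drawn: the two compounds have the same atoms and bonds and differ only in configuration as drawn: 1 of 1 stereo elements differ; a stereocentre at a saturated ring carbon is drawn S in compound 1 and R in compound 4. Compound 4 is thus the mirror image of compound 1 at its single stereocentre. Going by the values given here, no pair of mirror-image compounds has been measured here, so the size of such a step is not yet established. Compound 4 is expected to give a higher number than compound 1, with the step from a 9.5-fold higher number from compound 1 to compound 4 (0.98 log units; beyond the scatter) estimated as a clear loss in this assay. The estimate for compound 4 is 600 nM, within a range from 150 nM to 3000 nM.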

Compound 4, concentration for 90% inhibition: > 1500 nM
Compound 4 was reported as a limit; the forecaster's own chance of this, stated with the estimate: 30%; middle value at least 2.5-fold (0.39 log units) from the limit.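

Among the compounds shown, this is the first pair that changes nothing but the configuration at the single stereocentre, and in this assay that change alone gives an at least 23-fold higher number from compound 1 to compound 4 (1.37 log units; beyond the scatter). Compound 4 gives > 1500 nM as a limit and not a number. The loss can be traced to the configuration at this one centre, because no atom or bond changes: the fact that compounds 1 and 4 differ only in the configuration as drawn.

From the compounds shown here alone, whether the same preference for the S configuration as drawn would hold with an amine or a longer chain in place of the hydroxyl group of compound 1 stays open. Compound 3 has no mirror-image partner among the compounds shown, so the size of this step in that compound is also unknown.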